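A few compounds are considered here, and "the series" means these few. Any claim that something is new, unique, unknown or untested is made for them only; others in the source may bear on it.

Measured compounds:
compound 1 `Cc1c(-c2cc(Cl)cc(Cl)c2)c(C(=O)O)nn1-c1nc(-c2cccnc2)c(SC(C)C)s1`: "not active" (no number reported)
compound 2 `COc1cncc(-c2c(C)nn(-c3nc(-c4ccc(Cl)c(Cl)c4)c(SC(C)C)s3)c2C(=O)O)c1`: 21000 nM
compound 3 `Cc1nn(-c2nc(-c3ccc(Cl)c(Cl)c3)c(SC(C)C)s2)c(C(=O)O)c1-c1cccc(C(F)(F)F)c1`: 22000 nM

In a functional assay on BJAB cells (Homo sapiens) for antiproliferative activity, with a stated time of 4 days (a higher number here means that more compound is needed for the effect, a lower number that less compound is needed), compound 1 is reported only as "not active" (no number reported), so no number marks where it stands; compound 2 gives 21000 nM and compound 3 gives 22000 nM, both weak. Among the measured compounds shown here, the one single-point step among the measured compounds, a 1.0-fold higher number from compound 2 to compound 3 (0.02 log units; within the scatter), shows that swapping the aryl group on the pyrazole carbon leaves the result unchanged within the scatter.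

Compound 4 `Cc1oncc1-c1nc(-n2nc(C(=O)O)c(-c3cc(Cl)cc(Cl)c3)c2C)sc1SC(C)C` differs from compound 1 by 5-methyl-1,2-oxazol-4-yl in place of pyridin-3-yl on an aromatic carbon. For the measured compounds named here, no measured step touches this position on the shared core, and compound 1 itself has no number, so the expectation for compound 4 rests only on the weak values of compound 2 and compound 3 and on the absence of any reported activity for compound 1. The change from compound 1 to compound 4 is therefore expected to give, at best, a result in the same weak region as compound 2 and compound 3, with a real chance that again only an absence of activity is reported. Compound 4 in this assay is estimated at 30000 nM, within a range of 8000 nM to 100000 nM.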

Compound 4, half-maximal effective concentration: > 44000 nM
Compound 4 was reported as a limit (the forecaster's own chance of this, stated with the estimate: 50%); middle value at least 1.4-fold (0.16 log units) from the limit.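

In this assay compound 4 gives > 44000 nM, which is a limit and not a number. Among the compounds shown here, compound 1 is reported without a number, so no step from compound 1 to compound 4 can be read. The compounds shown leave open whether 5-methyl-1,2-oxazol-4-yl in place of pyridin-3-yl changes the result at all.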